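The source may report more compounds than this note shows. Statements on the series, on what has been measured and on what is new or still open speak of the compounds shown alone.

Measured compounds in a functional assay on CHO cells with adenosine receptor A1 (Homo sapiens) as the target, read by cAMP accumulation and immunoassay, with a stated time of 6 min, tested at 10 uM; a lower number here means a stronger effect, a higher number a weaker effect of the compound at the concentration tested:
compound 1 `Nc1scc(CN2CCN(c3ccc(F)cc3Cl)CC2)c1C(=O)c1ccc(Cl)cc1` — -70%
compound 2 `Nc1scc(CN2CCN(c3ccc(OC(F)(F)F)cc3)CC2)c1C(=O)c1ccc(Cl)cc1` — -74%
compound 3 `Nc1scc(CN2CCN(C3CCCCCC3)CC2)c1C(=O)c1ccc(Cl)cc1` — -25%

Compound 1 stands second highest of the three numbers in this assay; compound 2 lies nearest, the two being within the scatter, and compound 3 lies furthest, beyond the scatter. The steps show it: a number 4 percentage points lower from compound 1 to compound 2 (within the scatter), whereas a number 45 percentage points higher from compound 1 to compound 3 (beyond the scatter) and a number 49 percentage points higher from compound 2 to compound 3 (beyond the scatter).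

Compound 4 `Nc1scc(CN2CCN(c3cccc4ccccc34)CC2)c1C(=O)c1ccc(Cl)cc1` is not yet measured. Its change from compound 1: naphthalen-1-yl in place of 2-chloro-4-fluorophenyl on an amine nitrogen in a ring

The steps from compound 1 and from compound 2 to compound 3 bear on this only indirectly: both swap an aromatic group on the ring amine nitrogen for cycloheptyl, and both are large. The step from compound 1 to compound 2 swaps one aromatic group for another and stays within the scatter. Compound 4 keeps an aromatic group on that nitrogen, so the two aryl-to-aryl cases are the closer guide, and no step beyond the scatter is expected. The estimate for compound 4 is -68%, ranging from -88% to -45%, which means an expected step of a number 2 percentage points higher from compound 1 to compound 4 (within the scatter).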

Compound 4, a percentage reported as activity, at one concentration (the size of the read-out at that concentration, not a potency): -21%
The estimate for compound 4 lay 47 percentage points below the measured number; the measured number lies above the stated range.
By their numbers in this assay, from the lowest: compounds 2 and 1 (each within the scatter of the next); then compounds 3 and 4 (each within the scatter of the next).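

In this assay, an aromatic group on the ring amine nitrogen does not by itself keep the number low: the aryl swap that looked silent in a number 4 percentage points lower from compound 1 to compound 2 (within the scatter) gives way to large steps in a number 49 percentage points higher from compound 1 to compound 4 (beyond the scatter) and in a number 53 percentage points higher from compound 2 to compound 4 (beyond the scatter) once naphthalen-1-yl enters. With its two six-membered aromatic rings of carbon only, naphthalen-1-yl instead falls level with cycloheptyl, as a number 4 percentage points higher from compound 3 to compound 4 (within the scatter) shows, so among these four compounds only the single-ring aryl groups of compound 1 and compound 2 stand apart. No measurement at hand accounts for this split.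

Still open, going by these compounds, is whether the split follows the second fused ring or the way that ring system is attached, which naphthalen-2-yl on the same nitrogen would address. A benzyl group or a pyridine ring there would also show how far the low numbers extend beyond the substituted phenyl groups.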